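Chalcone amide series: tolerance on Vero cells

The compounds below may be only part of what the source reports. "The series", "measured", "known", "first", "only" and "open" are said of these compounds alone.

Compound 1 `CCCOc1ccc(C(=O)/C=C/c2ccc(C(=O)Nc3cccc(-c4cc(C(=O)OC)no4)c3)cc2)cc1` was run in an ADME assay on Vero cells (Chlorocebus sabaeus) for cytotoxicity, read by MTT assay, with a stated time of 72 h; a higher number here means that more compound is tolerated, a lower number that less compound is tolerated. In this assay compound 1 gives only a limit, > 40 ug/mL, so no single number is known for it. Compound 2 `CCOC(=O)c1nnn(-c2cccc(NC(=O)c3ccc(/C=C/C(=O)c4ccc(Cl)cc4)cc3)c2)c1C` has no result in this assay, "not determined" (no result reported). Going by the values given here, the only evidence on the series is the limit of > 40 ug/mL in this assay, at which 1 of the 2 values shown sits. Compound 3 `COC(=O)c1cc(-c2cccc(NC(=O)c3ccc(/C=C/C(=O)c4cccc(Cl)c4)cc3)c2)on1` differs from compound 1 by 3-chlorophenyl in place of 4-propoxyphenyl on a carbonyl carbon. Among the compounds with values here, with no measured step available, the step of a number no higher from compound 1 to compound 3 (the limit leaves the size open) is expected to stay within the scatter, in no clear direction. For compound 3 the estimate in this assay is 40 ug/mL, with a range from 20 ug/mL to 80 ug/mL.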

Compound 3, half-maximal cytotoxic concentration: > 2.5 ug/mL
Compound 3: a limit, no number (the forecaster's own chance of this, stated with the estimate: 60%); the middle value does not contradict the limit.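

Compound 1 and compound 3 both give only limits in this assay, so no step can be read between them. Going by these compounds, whether 3-chlorophenyl in place of 4-propoxyphenyl on a carbonyl carbon shifts tolerance, and by how much, stays open.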